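The source may hold more compounds than are shown below. What is called first, only, known or untested is meant among the compounds shown, and "the series" means these compounds.

Measured in a functional assay on MCF7 cells (Homo sapiens) for cytotoxicity, read by sulforhodamine B assay, with a stated time of 48 h; a higher number here means a weaker inhibitor, a lower number a stronger inhibitor:
- compound 1 `O=C(c1cccnc1)c1cc(Cl)ccc1O`: 29000 nM
- compound 2 `C=CCOc1ccc(Br)cc1C(=O)c1cccnc1`: 92000 nM

Of these two numbers, compound 2 at 92000 nM is the higher, and so the weaker inhibitor of the pair. Compound 1 at 29000 nM lies below it by a margin beyond the scatter.

The next compound is compound 3 `C=CCOc1ccc(Cl)cc1C(=O)c1cccnc1`, which carries chloro in place of bromo on an aromatic carbon, para to an allyloxy group: chloro in place of bromo on an aromatic carbon.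

Going by the values given here, no measured pair isolates this exchange, so the data give no direct size for it. With one ring substituent exchanged and the allyloxy group kept, no change beyond the scatter is expected in this assay. The estimated step of a 1.2-fold lower number from compound 2 to compound 3 (0.06 log units; within the scatter) stays within the scatter, with a slight shift to a lower number at most. For compound 3 the expected value is 80000 nM, with an estimated range of 40000 nM to 160000 nM.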

Compound 3, half-maximal inhibitory concentration: 54000 nM
Beside the measured number, compound 3's estimate is 1.5-fold (0.17 log units) above it, within the range that was stated.
By their numbers in this assay, from the lowest: compounds 1, 3 and 2 (each within the scatter of the next, the first and the last beyond it).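

In this assay chloro in place of bromo, on the aromatic carbon para to an allyloxy group, gives a 1.7-fold lower number from compound 2 to compound 3 (0.23 log units; within the scatter) and so does not separate the two halogens at this position. Going by these compounds alone, compound 3 also provides the first single-place reading at the oxygen: allyl in place of hydrogen, with chloro kept, gives a 1.9-fold higher number from compound 1 to compound 3 (0.27 log units; within the scatter) and stays inseparable from the hydrogen-bearing compound in this assay. No measurement bearing on the cause of either step is available.

Still open, from the compounds shown here alone, is whether a fluoro or a methoxy group at the halogen position would read differently from chloro and bromo. Also open, going by these compounds, is whether a longer chain or an amine on the oxygen would move the number beyond the scatter.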